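This account rests on a few compounds, and the source may have more. Where it says the series, first, only, none or still open, it means among the compounds named here.

Measured so far: compound 1 `O=C(Nc1cccc2nonc12)N1CCN(Cc2cccc(Oc3ccc(Cl)cc3)c2)CC1` and compound 2 `O=C(Nc1noc2cnccc12)N1CCN(Cc2cccc(Oc3ccc(Cl)cc3)c2)CC1`.

In an assay on isolated protein for inhibition of Fatty-acid amide hydrolase 1 (Rattus norvegicus), with a stated time of 60 min (a lower number here means a stronger inhibitor, a higher number a weaker inhibitor), compound 1 gives 120 nM. In this assay compound 2 gives 0.7 nM, the lowest of the two numbers. Compound 3 `O=C(Nc1cn2ccccc2n1)N1CCN(Cc2cccc(Oc3ccc(Cl)cc3)c2)CC1` differs from compound 2 by a group of 9 heavy atoms (7 carbon, 2 nitrogen; one five-membered aromatic ring with 2 hetero atoms, one six-membered aromatic ring with 1 hetero atom) in place of a group of 9 heavy atoms (6 carbon, 2 nitrogen, 1 oxygen; one five-membered aromatic ring with 2 hetero atoms, one six-membered aromatic ring with 1 hetero atom), on an amide-type nitrogen. Among the measured compounds shown here, only one measured step touches this position, a 170-fold lower number from compound 1 to compound 2 (2.23 log units; beyond the scatter), which shows that exchanging the group on the amide-type nitrogen can move the number a great deal. For the measured compounds named here, that step concerns a different exchange, so its direction does not carry over; the size is the only guide. Compound 3 is therefore expected to give 8 nM, within 1 nM to 60 nM, a step of an 11-fold higher number from compound 2 to compound 3 (1.06 log units; beyond the scatter).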

Compound 3, half-maximal inhibitory concentration: > 10000 nM
Compound 3 gave a limit, no number (the forecaster's own chance of this, stated with the estimate: 3%); middle value at least 1200-fold (3.09 log units) from the limit.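

In this assay compound 3 stands at a limit, not a number: the limit of > 10000 nM in this assay, at which 1 of the 3 values shown sits. The entering and leaving groups have the same ring description, yet the exchange gives an at least 14000-fold higher number from compound 2 to compound 3 (4.15 log units; beyond the scatter), so that description does not settle the result at this position. The change also falls short of the group in the weaker earlier compound, with an at least 83-fold higher number from compound 1 to compound 3 (1.92 log units; beyond the scatter), so exchanges here can move the number in either direction.

From the compounds shown here alone, how a plain phenyl or a pyridyl group on the amide-type nitrogen would stand remains open. The compounds shown also leave open how far past its limit compound 3 lies.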